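Changing One Side Chain on a Shared Core

The compounds below may be only part of what the source reports. "The series", "measured", "known", "first", "only" and "open" are said of these compounds alone.

Of the compounds shown here, three with a shared core have been tested in a functional assay (trachea) with Cavia porcellus as the target; on this read-out lower numbers stand for an effect already at smaller amounts and higher numbers for an effect only at larger amounts of compound. Compound 1 `CCCn1c(=O)n(CCC#N)c(=O)c2[nH]cnc21` gives 1700 nM, compound 2 `CCCn1c(=O)n(CCO)c(=O)c2[nH]cnc21` gives 510 nM, and compound 3 `CCCn1c(=O)n(CCCOC)c(=O)c2[nH]cnc21` gives 2900 nM. Compound 3 lies within the scatter of compound 1, and compound 2 stands clearly apart from both.

The next compound, compound 4 `CCCn1c(=O)n(CC(C)=O)c(=O)c2[nH]cnc21`, has acetyl in place of 2-methoxyethyl on a saturated chain carbon bound to an aromatic nitrogen. Going by the values given here, no measured step makes this exact swap. The closest evidence comes from changes to the same chain, which gave a 1.7-fold higher number from compound 1 to compound 3 (0.23 log units; within the scatter), a 3.3-fold lower number from compound 1 to compound 2 (0.52 log units; beyond the scatter) and a 5.7-fold higher number from compound 2 to compound 3 (0.75 log units; beyond the scatter). Only compound 2, at 510 nM, carries a hydroxy, and compound 4 does not, so a number nearer compound 3 is expected. The expected change in this assay is small, a 1.9-fold lower number from compound 3 to compound 4 (0.29 log units; within the scatter), and no step beyond the scatter is anticipated. For compound 4 the estimated value is 1500 nM, with an expected range of 500 nM to 4000 nM.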

Compound 4, half-maximal effective concentration: 14900 nM
Compound 4: middle estimate off by 9.9-fold (1.00 log units), on the low side; the whole stated range lies below it.
By their numbers in this assay, from the lowest: compound 2; then compounds 1 and 3 (each within the scatter of the next); then compound 4.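

Going by these compounds alone, the chain on this nitrogen can move the number further than the earlier compounds suggested: with 2-oxopropyl in place of 3-methoxypropyl, there is a 5.1-fold higher number from compound 3 to compound 4 (0.71 log units; beyond the scatter), even though the counted hydrogen-bond donors and acceptors stay the same. Lacking a hydroxy therefore does not place a compound at one common level, since compounds 1, 3 and 4 all lack it, yet there is an 8.8-fold higher number from compound 1 to compound 4 (0.94 log units; beyond the scatter). The full span at this position also widens, with a 29-fold higher number from compound 2 to compound 4 (1.47 log units; beyond the scatter), the largest step in the set.

No measurement shown here explains why the acetyl change has this effect. The compounds shown leave open how an amine or a carboxylic acid on this chain would read, and whether a longer chain carrying the same carbonyl would stay near compound 4.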